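A few compounds are considered here, and "the series" means these few. Any claim that something is new, unique, unknown or untested is made for them only; others in the source may bear on it.

Working notes on the series.

Compound 1 `COc1cc(N2CCCNCC2)cnc1Cl` is the reference point. Going by the values given here, in an assay on HEK293 cells for displacement of a labelled ligand from Neuronal acetylcholine receptor; alpha4/beta2 (Homo sapiens) (a lower number here means a stronger inhibitor, a higher number a weaker inhibitor), compound 1 gives 0.676 nM, the second highest of the three numbers measured so far. Nearest to it is compound 2 `C=COc1cc(N2CCCNCCC2)cnc1Br`, which in this assay gives 0.38 nM, within the scatter of compound 1. Furthest is compound 3 `Clc1ncc(N2CCCNCC2)cc1Br`, which in this assay gives 1.41 nM; the step of a 2.1-fold higher number from compound 1 to compound 3 (0.32 log units; beyond the scatter) is modest but beyond the scatter, and it comes from bromo in place of methoxy on an aromatic carbon.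

Compound 4 `COc1cncc(N2CCCNCC2)c1` differs from compound 1 in one place: hydrogen in place of chloro on an aromatic carbon. Among the compounds with values here, no measured step bears directly on this change. Within the data shown here, the only measured step, a 2.1-fold higher number from compound 1 to compound 3 (0.32 log units; beyond the scatter), concerns the methoxy position, not the chloro, and all three measured compounds keep a chloro or bromo group on the carbon next to the ring nitrogen. Among the measured compounds shown here, compound 4 is the first to lack it, so the direction rests on no measured precedent and the range must be wide. A rise in the number, beyond the scatter, is the working expectation for compound 4, amounting to a 3.7-fold higher number from compound 1 to compound 4 (0.57 log units; beyond the scatter). The estimate for compound 4 in this assay is 2.5 nM, with a range from 0.6 nM to 10 nM.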

Compound 4, half-maximal inhibitory concentration: 1.91 nM
Beside the measured number, compound 4's estimate is 1.3-fold (0.12 log units) above it; low and high end bracket the measured number.
By their numbers in this assay, from the lowest: compounds 2 and 1 (each within the scatter of the next); then compounds 3 and 4 (each within the scatter of the next).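

In this assay, going by these compounds alone, the step of a 2.8-fold higher number from compound 1 to compound 4 (0.45 log units; beyond the scatter) is the first reading on the chloro group itself, on the aromatic carbon next to the ring nitrogen, and it shows that this group contributes measurably to the number while the methoxy group stays in place. Its loss is not fatal to binding, since compound 4, carrying only hydrogen there, still gives 1.91 nM and the step remains modest. Together with the step of a 2.1-fold higher number from compound 1 to compound 3 (0.32 log units; beyond the scatter), this means both single changes shown on the aromatic ring of compound 1 raise the number, so compound 1 now stands below both of its one-place neighbours, although no data shown bear on what lies behind either step.

Going by these compounds, with only chloro and hydrogen compared directly at this position, the two points fix no trend, and it remains open whether fluoro, methyl, nitrile or an amine there would match chloro, fall near hydrogen or go beyond both. Also open, on these data alone, is whether the same step holds on other versions of the core, such as one with bromo or a vinyloxy group in place of the methoxy group.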